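The compounds below may be only part of what the source reports. "The series", "measured", "known", "first", "only" and "open" are said of these compounds alone.

Working notes on the series. Among the measured compounds shown here, compound 3 `O=C1NC(=S)S/C1=C\C=C\c1ccccc1O` stands lowest of the three numbers so far: in a functional assay on DLD-1 cells (Homo sapiens), read by microscopy and crystal violet staining, with a stated time of 20 h, tested at 10 ug/mL (on this read-out lower numbers stand for less inhibition and higher numbers for more inhibition at the one concentration tested (going by the name of the read-out)), compound 3 gives 65%. Compound 2 `COc1ccccc1/C=C/C=C1\SC(=S)NC1=O` gives 69% in this assay, and the step of a number 4 percentage points lower from compound 2 to compound 3 (within the scatter) lies within the scatter, so no order between compound 2 and compound 3 is claimed. Compound 1 `COc1cccc(COc2ccccc2/C=C/C=C2\SC(=S)NC2=O)c1` gives 82%, and the step of a number 13 percentage points lower from compound 1 to compound 2 (beyond the scatter) is the only movement beyond the scatter in the set.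

Compound 4 `Cc1ccccc1COc1ccccc1/C=C/C=C1\SC(=S)NC1=O` is not yet measured. Its change from compound 3 is 2-methylbenzyl in place of hydrogen on an oxygen on an aromatic ring. Both measured steps bear on it, since together they run from compound 1 to compound 3 by taking away the aryl part and then the methyl at this same oxygen; the step to compound 4 runs the other way, putting a 2-methylbenzyl where compound 3 carries hydrogen. Compound 4 is therefore expected to land near compound 1, because the step of a number 13 percentage points lower from compound 1 to compound 2 (beyond the scatter) was modest and the step of a number 4 percentage points lower from compound 2 to compound 3 (within the scatter) was within the scatter. For compound 4 the estimated step is a number 15 percentage points higher from compound 3 to compound 4 (beyond the scatter), toward more inhibition. The estimate for compound 4 in this assay is 80%, with a range from 68% to 90%.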

Compound 4, a percentage reported as inhibition, at one concentration (the size of the read-out at that concentration, not a potency): 73%
For compound 4 the middle estimate is 7 percentage points above the measured one, and the stated range covers the measured number.
By their numbers in this assay, from the lowest: compounds 3, 2, 4 and 1 (each within the scatter of the next, the first and the last beyond it).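

In this assay, 2-methylbenzyl on the oxygen on an aromatic ring, in place of hydrogen, does not move the number beyond the scatter (a number 8 percentage points higher from compound 3 to compound 4 (within the scatter)). The same holds with 2-methylphenyl on the saturated chain carbon, both in place of hydrogen (a number 4 percentage points higher from compound 2 to compound 4 (within the scatter)) and in place of 3-methoxyphenyl (a number 9 percentage points lower from compound 1 to compound 4 (within the scatter)), so an aryl part at this position does not by itself separate compound 4 from any of the three earlier compounds. Nothing at hand accounts for this result.

Only compound 1 and compound 3 stand beyond the scatter of each other, so the three aryl-bearing and aryl-free forms cannot be ranked finely at this single concentration. As far as these compounds go, how an amine or a carboxylic acid on the aryl ring, or a longer chain in place of 2-methylbenzyl, would read at this oxygen remains open.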